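Halogen exchange on the aryl urea of compound 2

This account rests on a few compounds, and the source may have more. Where it says the series, first, only, none or still open, it means among the compounds named here.

Compound 2 `O=C(Nc1ccc(F)cc1)Nc1nnc(Sc2ncnc3scc(-c4ccncc4)c23)s1` gives 970 nM in a functional assay on PC-3 cells (Homo sapiens) for antiproliferative activity, read by MTT assay, with a stated time of 48 h (on this read-out lower numbers stand for stronger inhibition and higher numbers for weaker inhibition), the lowest of the two numbers in hand. Compound 1 `Cc1cccc(NC(=O)Nc2nnc(Sc3ncnc4scc(-c5ccncc5)c34)s2)c1` gives 5200 nM in this assay. Going by the values given here, the one measured step, a 5.4-fold lower number from compound 1 to compound 2 (0.73 log units; beyond the scatter), came from exchanging the whole aryl group on the urea nitrogen and is the only guide. Compound 3 `O=C(Nc1ccc(Cl)cc1)Nc1nnc(Sc2ncnc3scc(-c4ccncc4)c23)s1` differs from compound 2 only by chloro in place of fluoro on an aromatic carbon. Among the compounds with values here, no measured step exchanges one halogen for another at this position, so the step from compound 1 to compound 2 bears on the new change only loosely: it shows that the aryl substituent matters, not what a second halogen does. A step within the usual scatter is therefore expected, a 1.1-fold lower number from compound 2 to compound 3 (0.03 log units; within the scatter). Compound 3 is estimated at 900 nM in this assay, with a range of 350 nM to 2500 nM.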

Compound 3, half-maximal inhibitory concentration: 7700 nM
Beside the measured number, compound 3's estimate is 8.6-fold (0.93 log units) below it; the measured number lies above the stated range.
By their numbers in this assay, from the lowest: compound 2; then compounds 1 and 3 (each within the scatter of the next).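

At this position the identity of the halogen matters: in this assay, chloro in place of fluoro gives a 7.9-fold higher number from compound 2 to compound 3 (0.90 log units; beyond the scatter), a change that the earlier exchange of the whole aryl group could not isolate. The gain seen with compound 2 therefore does not extend to every 4-halophenyl urea, as 4-chlorophenyl in place of 3-methylphenyl gives only a 1.5-fold higher number from compound 1 to compound 3 (0.17 log units; within the scatter), which lies within the scatter. No measurement here accounts for the difference between fluoro and chloro.

The compounds shown leave open how hydrogen, bromo, methoxy or an amine would read at this position, and so whether fluoro stands alone or is one of several favourable groups. Also open, on these data alone, is whether the exchange of fluoro for chloro would give a step of similar size elsewhere on the aryl ring.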